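This account rests on a few compounds, and the source may have more. Where it says the series, first, only, none or still open, it means among the compounds named here.

Compound 1 `COc1ccc(C2=NN(c3ccccc3)C(c3ccc(C)cc3)C2S(=O)(=O)CC2=NCCO2)cc1` shows an activity of 64.3% in a functional assay, tested at 75 ug/mL; on this read-out higher numbers stand for a stronger effect at the one concentration tested and lower numbers for a weaker effect.
Compound 2 `COc1ccc(C2=NN(c3ccccc3)C(c3ccc(C)cc3)C2S(=O)(=O)CC2=NCCS2)cc1` shows an activity of 43.9% in this assay.
Compound 3 `O=S(=O)(CC1=NCCS1)C1=NNCC1c1ccc(Cl)cc1` is reported in this assay as "not active" (no number reported), without a number.

Compounds 1 and 2 share one core and differ in a single place: a group of 5 heavy atoms (3 carbon, 1 nitrogen, 1 oxygen; one five-membered non-aromatic ring with 2 hetero atoms) in place of a group of 5 heavy atoms (3 carbon, 1 nitrogen, 1 sulfur; one five-membered non-aromatic ring with 2 hetero atoms), on a saturated chain carbon bound to a sulfonyl sulfur. That exchange brought a number 20.4 percentage points higher from compound 2 to compound 1 (beyond the scatter). Compound 4 `O=S(=O)(CC1=NCCO1)C1=NNCC1c1ccc(Cl)cc1` is not yet measured; it carries the same kind of change on the core of compound 3, namely (a group of 5 heavy atoms (3 carbon, 1 nitrogen, 1 oxygen; one five-membered non-aromatic ring with 2 hetero atoms) in place of a group of 5 heavy atoms (3 carbon, 1 nitrogen, 1 sulfur; one five-membered non-aromatic ring with 2 hetero atoms), on a saturated chain carbon bound to a sulfonyl sulfur). How the core of compound 3 differs from that of compound 2 is not broken down here.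

Compound 3 stands in this assay at "not active" (no number reported), with no number behind it. The starting point for compound 4 is thus low. Compound 4 is therefore expected to reach only 15% in this assay, with a likely range from 0% to 40%, and a real chance that it too is reported only as not active.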

Compound 4, a percentage reported as activity, at one concentration (the size of the read-out at that concentration, not a potency): "not active" (no number reported)
Nothing numeric was reported for compound 4; there is nothing to compare the estimate with.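

Compound 3 and compound 4 are both reported without a number, so no step can be read between them. From the compounds shown here alone, whether exchanging the sulfur-containing ring for the oxygen-containing ring changes activity on this core stays open. No supporting data bear on this result.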